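The compounds below may be only part of what the source reports. "The series", "measured", "known", "first", "only" and "open" are said of these compounds alone.

Compound 1 `COOC1(OOC)CCCCCCCCCCC1` gives 1500 nM
Compound 2 `CCOC(C)OOC1(OOC)CCCCCCCCCCC1` gives 12000 nM
Compound 3 `C=C(C)COOC(CCCC)(CCCC)OOC` gives 15000 nM

All three values come from a functional assay on FM3A cells (Mus musculus) for cytotoxicity; a higher number here means that more compound is needed for the effect, a lower number that less compound is needed. Compound 2 lies within the scatter of compound 3, and its number is well above that of compound 1. The unmeasured compound 4 `COOC1(OOCCC(=O)OC)CCCCCCCCCCC1` differs from compound 2 in one place: 2-(methoxycarbonyl)ethyl in place of 1-ethoxyethyl on an oxygen. In words, 2-(methoxycarbonyl)ethyl stands in place of 1-ethoxyethyl on an oxygen.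

Among the measured compounds shown here, only one measured step bears on this change. It is an 8.0-fold higher number from compound 1 to compound 2 (0.90 log units; beyond the scatter), a modest step that came with 1-ethoxyethyl in place of methyl on an oxygen. For the measured compounds named here, no measured pair compares 1-ethoxyethyl with 2-(methoxycarbonyl)ethyl directly. Neither group in the present change is methyl, so a repeat of that step is not expected, and any shift in this assay is expected to stay within the scatter. The estimated step is a 1.5-fold lower number from compound 2 to compound 4 (0.18 log units; within the scatter). For compound 4 the estimate is 8000 nM, with an expected range from 2500 nM to 25000 nM.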

Compound 4, half-maximal effective concentration: 1400 nM
Estimate against measurement, compound 4: 5.7-fold (0.76 log units) above, outside the stated range (below it).
By their numbers in this assay, from the lowest: compounds 4 and 1 (each within the scatter of the next); then compounds 2 and 3 (each within the scatter of the next).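

In this assay the group on this oxygen, whose other neighbour is oxygen, can also lower the number: the change from 1-ethoxyethyl to 2-(methoxycarbonyl)ethyl gave an 8.6-fold lower number from compound 2 to compound 4 (0.93 log units; beyond the scatter) and so cancelled the earlier rise. Replacing methyl with a bigger group therefore need not raise the number, as a 1.1-fold lower number from compound 1 to compound 4 (0.03 log units; within the scatter) stays within the scatter, and compound 4 goes against the direction set by compound 2. Nothing available explains why these two groups differ.

As far as these compounds go, it remains open whether a carboxylic acid in place of the methyl ester, or a longer chain before the carbonyl, would keep the number close to that of compound 4. Also open, from the compounds shown here alone, is which part of 1-ethoxyethyl goes with the higher number of compound 2.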